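The source may report more compounds than this note shows. Statements on the series, on what has been measured and on what is new or still open speak of the compounds shown alone.

Compound 1 `O=C(/C=C/c1ccc2c(c1)B(O)OC2)c1ccco1`, compound 2 `O=C(/C=C/c1ccc2c(c1)B(O)OC2)c1ccc([N+](=O)[O-])cc1` and compound 3 `CCOC(=O)c1ccc(C(=O)/C=C/c2ccc3c(c2)B(O)OC3)cc1` share one core and differ only in the group on the carbonyl carbon. In a toxicity assay on MCF-10A cells (Homo sapiens) for cytotoxicity, read by MTT assay, with a stated time of 48 h (a higher number here means a weaker inhibitor, a lower number a stronger inhibitor), compound 1 gives 7400 nM, compound 2 gives 17500 nM and compound 3 gives 12900 nM; compound 1 holds the lowest number, and compound 3 lies within the scatter of it. Compound 4 `O=C(/C=C/c1ccc2c(c1)B(O)OC2)c1ccccc1F` is not yet measured. (2-fluorophenyl in place of furan-2-yl on a carbonyl carbon). Going by the values given here, the only measured step, a 1.4-fold lower number from compound 2 to compound 3 (0.13 log units; within the scatter), exchanges one group on an aromatic ring and stays within the scatter; no measured step replaces the whole ring, so no change beyond the scatter is expected. Compound 4 is therefore estimated at 9500 nM, between 4000 nM and 22000 nM, which means an expected step of a 1.3-fold higher number from compound 1 to compound 4 (0.11 log units; within the scatter).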

Compound 4, half-maximal inhibitory concentration: 25400 nM
The estimate for compound 4 lay 2.7-fold (0.43 log units) below the measured number; measured number outside the range, above it.
By their numbers in this assay, from the lowest: compounds 1, 3, 2 and 4 (each within the scatter of the next, the first and the last beyond it).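

Going by these compounds alone, replacing a whole ring at this position moves the number further than the one measured exchange of a group on a ring. In this assay the change to 2-fluorophenyl from furan-2-yl on the carbonyl carbon gives a 3.4-fold higher number from compound 1 to compound 4 (0.54 log units; beyond the scatter) and so goes beyond the scatter, whereas a 1.4-fold lower number from compound 2 to compound 3 (0.13 log units; within the scatter) stays within it. No measurement available here explains this rise.

On these data alone, whether the rise follows from losing furan-2-yl or from the fluorine on the new ring stays open. A plain phenyl on the same carbonyl carbon would separate the two.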